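This account rests on a few compounds, and the source may have more. Where it says the series, first, only, none or still open, it means among the compounds named here.

The measured compounds:

Compound 1, `CCCCCCCCCCC(C)(C)NC(=O)c1c(OC)cc(OC)cc1OC`, in an assay on microsomes from liver for inhibition of sterol O-acyltransferase 1 (Rattus norvegicus) (on this read-out higher numbers stand for weaker inhibition and lower numbers for stronger inhibition), reaches only > 10000 nM, which is a limit of the measurement and not a number.
Compound 2, `CCCCCCCCCCCCn1nnc(C(NC(=O)c2c(C)cccc2C)c2ccccc2)n1`, in this assay gives 310 nM.
Compound 3, `CCCCCCCCCCCCn1nnc(C(NC(=O)c2ccccc2)c2ccccc2)n1`, in this assay gives 350 nM.

Compound 3 stands highest of the two numbers, but its nearest neighbour, compound 2, sits within the scatter of it: a 1.1-fold higher number from compound 2 to compound 3 (0.05 log units; within the scatter). The third value is a limit, (the limit of > 10000 nM in this assay, at which 1 of the 3 values shown sits), which sets compound 1 apart from the core shared by compounds 2 and 3.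

Compound 4, `CCCCCCCCCCCCn1nnc(C(NC(=O)c2cccc(Cl)c2)c2ccccc2)n1`, differs from compound 3 in one place: chloro in place of hydrogen on an aromatic carbon. For the measured compounds named here, only one measured step touches the same benzoyl ring, and it exchanged phenyl for 2,6-dimethylphenyl without moving the number beyond the scatter. Going by the values given here, no measured step introduces a chloro group anywhere, so no direction can be read from the data. A step within the scatter is therefore expected in this assay.

Compound 4 is expected to give 320 nM, with a range from 120 nM to 900 nM. The expected step of a 1.1-fold lower number from compound 3 to compound 4 (0.04 log units; within the scatter) stays within the scatter.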

Compound 4, half-maximal inhibitory concentration: 250 nM
Beside the measured number, compound 4's estimate is 1.3-fold (0.11 log units) above it, and the stated range covers the measured number.
By their numbers in this assay, from the lowest: compounds 4, 2 and 3 (each within the scatter of the next). At a limit, above all of these: compound 1.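

Read in this assay, the earlier compounds had shown only methyl groups on this benzoyl ring, and a chloro group on an aromatic carbon, meta to a large group, now adds a first halogen, with a 1.4-fold lower number from compound 3 to compound 4 (0.15 log units; within the scatter) and thus no change that can be told from the scatter. Replacing 2,6-dimethylphenyl with 3-chlorophenyl on the carbonyl carbon gives a 1.2-fold lower number from compound 2 to compound 4 (0.09 log units; within the scatter) and so shows that two different substitution patterns on this ring also cannot be told apart. Nothing shown here bears on a cause for these steps.

As far as these compounds go, whether an amine, a carboxylic acid or a nitrile in place of the chloro group would stay within the scatter remains open. Also open, from the compounds shown here alone, is whether a chloro group elsewhere on this ring, or a shorter chain on the shared core, would move the number beyond it.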